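Pyridin-2-yl replacing the cyanofuran on a shared core

This account rests on a few compounds, and the source may have more. Where it says the series, first, only, none or still open, it means among the compounds named here.

The series is measured in a functional assay on CHO-K1 cells for antagonist activity at adenosine receptor A1 (Homo sapiens), read by a beta-galactosidase reporter and cAMP accumulation, with stated times of 15 min and 6 h; on this read-out higher numbers stand for weaker inhibition and lower numbers for stronger inhibition. Compound 1 `N#Cc1ccc(-c2nc(N)c3cc(Cc4ccccc4)sc3n2)o1` gives 3160 nM and holds the highest of the two numbers shown. Compound 2 `Nc1nc(-c2ccccc2)nc2sc(-c3ccccc3)cc12` gives 237 nM, a lower number than compound 1 by a gap beyond the scatter. Compound 3 `Nc1nc(-c2cccc(C(F)(F)F)c2)nc2sc(Cc3ccccc3)cc12` gives > 1000 nM, which is a limit of this assay and not a number (the limit of > 1000 nM in this assay, at which 1 of the 3 values shown sits). Among the compounds with values here, no two of the measured compounds differ in a single place, so no measured step is available.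

Compound 4 `Nc1nc(-c2ccccn2)nc2sc(Cc3ccccc3)cc12` is the next compound. It differs from compound 1 by pyridin-2-yl in place of 5-cyanofuran-2-yl on an aromatic carbon. The series gives no measured step for this kind of change, so the direction rests only on the spread of numbers shown. Compound 4 is expected to give 900 nM, with a range from 200 nM to 4000 nM. The step of a 3.5-fold lower number from compound 1 to compound 4 (0.55 log units; beyond the scatter) is expected to be a move to a lower number, of a size somewhat beyond the scatter, but the uncertainty is wide and a limit is possible.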

Compound 4, inhibition constant: 3710 nM
Compound 4: middle estimate off by 4.1-fold (0.62 log units), on the low side; the measured number falls inside the stated range.
By their numbers in this assay, from the lowest: compound 2; then compounds 1 and 4 (each within the scatter of the next).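

Pyridin-2-yl in place of 5-cyanofuran-2-yl on the aromatic carbon between two ring nitrogen atoms gives a 1.2-fold higher number from compound 1 to compound 4 (0.07 log units; within the scatter) in this assay. Within the data shown here, this is the first single-place comparison, and it shows that this position accepts a five-membered aromatic ring carrying a nitrile and a six-membered aromatic ring with one hetero atom with no change beyond the scatter. The nitrile is therefore not needed to keep the number at this level, at least with the shared core of compounds 1 and 4.

Compound 3 gives > 1000 nM, a limit of the assay and not a number, so its step to compound 4 at this position cannot be read: the limit of > 1000 nM in this assay, at which 1 of the 4 values shown sits. From the compounds shown here alone, what an amine or a carboxylic acid in place of the ring at this carbon would give remains open.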